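From 4-methoxyphenyl to 1H-pyrrol-2-yl on a carbonyl carbon

A few compounds are considered here, and "the series" means these few. Any claim that something is new, unique, unknown or untested is made for them only; others in the source may bear on it.

Measured so far in a functional assay on NCI-H1650 cells (Homo sapiens) for inhibition, read by sulforhodamine B assay, with a stated time of 3 days; on this read-out higher numbers stand for weaker inhibition and lower numbers for stronger inhibition:
- compound 1 `O=C1Nc2ccc(F)cc2/C1=C\C(=O)c1cccs1` gives 3220 nM
- compound 2 `O=C1Nc2ccc(F)cc2/C1=C\C(=O)c1cnc2ccc(Cl)nn12` gives 2730 nM
- compound 3 `COc1ccc(C(=O)Nc2ccc3c(c2)/C(=C/Nc2cccc(N4CCN(C)CC4)c2)C(=O)N3)cc1` gives 1870 nM

Compound 3 cannot be told apart from compound 1 or compound 2, as all three values lie within the usual scatter of one another. Compound 4 `CN1CCN(c2cccc(N/C=C3\C(=O)Nc4ccc(NC(=O)c5ccc[nH]5)cc43)c2)CC1` alters compound 3 in one place: 1H-pyrrol-2-yl in place of 4-methoxyphenyl on a carbonyl carbon is the counted difference, with 1H-pyrrol-2-yl in place of 4-methoxyphenyl on a carbonyl carbon. Going by the values given here, no two measured compounds differ in only one place, so the data offer no direct guide to this change. Compound 1 at 3220 nM and compound 3 at 1870 nM have quite different structures yet fall within the scatter, so no shift beyond the scatter is expected in this assay here. The expected 1.0-fold lower number from compound 3 to compound 4 (0.02 log units; within the scatter) is therefore small. For compound 4 the estimated value is 1800 nM, with 600 nM to 5400 nM as its expected range.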

Compound 4, half-maximal inhibitory concentration: 7560 nM
Beside the measured number, compound 4's estimate is 4.2-fold (0.62 log units) below it; measured number above the stated range.
By their numbers in this assay, from the lowest: compounds 3, 2 and 1 (each within the scatter of the next); then compound 4.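

In this assay, 1H-pyrrol-2-yl in place of 4-methoxyphenyl on the carbonyl carbon gives a 4.0-fold higher number from compound 3 to compound 4 (0.61 log units; beyond the scatter), which means weaker inhibition. Going by these compounds alone, this shows that the group at this position can shift the result beyond the scatter, something the earlier compounds, all within the scatter of one another, could not show. No measurement at hand explains the shift.

This single pair cannot separate the change in ring size from the added hydrogen-bond donor. On these data alone, it also remains open whether a plain phenyl or a dimethylaminomethyl group here would match compound 3 or compound 4.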